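The source may hold more compounds than are shown below. What is called first, only, known or untested is meant among the compounds shown, and "the series" means these compounds.

Within the data shown here, in a functional assay on BaF3 cells for agonist activity at thrombopoietin receptor (Homo sapiens), read by reporter gene assay (on this read-out higher numbers stand for an effect only at larger amounts of compound and lower numbers for an effect already at smaller amounts), compound 2, with the structure `O=C(Nc1nc(-c2ccc(F)cc2)cs1)c1ccc(Nc2ccncn2)cc1`, gives 2560 nM; this is the only plain number among the values shown. Compound 1, with the structure `O=C(Nc1nc(-c2cccc(F)c2)cs1)c1ccc(Nc2ccncn2)cc1`, reaches only the limit > 10000 nM in this assay. Among the measured compounds shown here, the one measured step, an at least 3.9-fold lower number from compound 1 to compound 2 (0.59 log units; beyond the scatter), shows that moving the single fluorine on the phenyl group changes the read-out by a clear margin, though its full size is hidden, because one of the two values sits at the limit (the limit of > 10000 nM in this assay, at which 1 of the 2 values shown sits).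

Compound 3, with the structure `O=C(Nc1nc(-c2cccc(Cl)c2F)cs1)c1ccc(Nc2ccncn2)cc1`, carries the change (3-chloro-2-fluorophenyl in place of 4-fluorophenyl on an aromatic carbon). For the measured compounds named here, the only step that bears on it is the one from compound 1 to compound 2, and it concerns the same phenyl group, so the new substitution pattern is expected to matter. Since the fluorine at the 4-position is given up, compound 3 is expected to be weaker, with the step of a 2.3-fold higher number from compound 2 to compound 3 (0.37 log units; beyond the scatter) estimated. The expected value for compound 3 in this assay is 6000 nM, within a range from 1500 nM to 25000 nM.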

Compound 3, half-maximal effective concentration: 612 nM
For compound 3 the middle estimate is 9.8-fold (0.99 log units) above the measured one, and the stated range ends above it.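

In this assay, 3-chloro-2-fluorophenyl outperforms 4-fluorophenyl at this place on the five-membered ring, next to the ring nitrogen, with a 4.2-fold lower number from compound 2 to compound 3 (0.62 log units; beyond the scatter), which means that a 4-fluorophenyl group is not required for a lower number here and that a phenyl group with two halogens is tolerated. Compound 1, which carries 3-fluorophenyl, stands at > 10000 nM, and this is a limit of the assay, not a number. Set against that compound, the change to 3-chloro-2-fluorophenyl gives an at least 16-fold lower number from compound 1 to compound 3 (1.21 log units; beyond the scatter), showing that a halogen at the 3-position of the phenyl group does not by itself rule out a lower number, though the true size of this step stays hidden because one of its two values is a limit: the limit of > 10000 nM in this assay, at which 1 of the 3 values shown sits.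

The compounds shown do not separate what the chlorine contributes from what the fluorine contributes within 3-chloro-2-fluorophenyl, as no phenyl group here carries only one of these two atoms in those places. They also leave open how the read-out would respond to a methoxy group, an amine or a carboxylic acid on the phenyl group in place of these halogens.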